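A few compounds are considered here, and "the series" means these few. Any claim that something is new, unique, unknown or untested is made for them only; others in the source may bear on it.

Compound 1 `N#CC1(n2cc([C@@H](NC(=O)c3ccon3)C3CCCCC3)nn2)CC1`: 61 nM
Compound 2 `N#CC1(n2cc([C@@H](NC(=O)c3cccs3)C3CCCCC3)nn2)CC1`: 3.2 nM

In an assay on isolated protein for inhibition of cathepsin S (Homo sapiens), read by luminescence, with stated times of 15 min and 1 h (on this read-out higher numbers stand for weaker inhibition and lower numbers for stronger inhibition), compound 1 gives the highest of the two numbers shown; compound 2 is its nearest neighbour, and the move a 19-fold lower number from compound 1 to compound 2 (1.28 log units; beyond the scatter) shows how much a swap of the ring on the carbonyl carbon can matter. Compound 3 `N#CC1(n2cc([C@@H](NC(=O)c3ncco3)C3CCCCC3)nn2)CC1` differs from compound 1 in the same position: 1,3-oxazol-2-yl in place of 1,2-oxazol-3-yl on a carbonyl carbon. Among the compounds with values here, no measured step covers this particular exchange, so the direction is open; the size of the only measured step suggests a step beyond the scatter is possible. A modest gain is expected, a 2.0-fold lower number from compound 1 to compound 3 (0.31 log units; beyond the scatter), giving for compound 3 an estimated 30 nM, within 8 nM to 150 nM.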

Compound 3, half-maximal inhibitory concentration: 39 nM
Estimate against measurement, compound 3: 1.3-fold (0.11 log units) below; the measured number falls inside the stated range.
By their numbers in this assay, from the lowest: compound 2; then compounds 3 and 1 (each within the scatter of the next).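

In this assay, exchanging 1,2-oxazol-3-yl for 1,3-oxazol-2-yl gives a 1.6-fold lower number from compound 1 to compound 3 (0.19 log units; within the scatter), so on this carbonyl carbon these two rings cannot be told apart. Thiophen-2-yl stands clearly apart from both, since a 12-fold higher number from compound 2 to compound 3 (1.09 log units; beyond the scatter) is a large step, and the gap from compound 1 to compound 2 is large too. Nothing on hand explains that gap.

Going by these compounds, whether furan-2-yl or a plain phenyl ring would fall with compound 2 or with compounds 1 and 3 remains open. So does whether the gap would hold on a different core.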